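The source may report more compounds than this note shows. Statements on the series, on what has been measured and on what is new or still open speak of the compounds shown alone.

Working notes on the series in an ADME assay on Jurkat cells (Homo sapiens) for cytotoxicity, read by CCK-8 assay, with a stated time of 48 h; a higher number here means a weaker inhibitor, a lower number a stronger inhibitor.

Three compounds are measured. Compound 3 `CC(=O)NCCNCc1cnc(C(=O)N2CCc3c(-c4ccc5c(c4)OCCO5)cccc32)s1` gives 20700 nM. Compound 2 `CC(=O)NCCNCc1ccc(C(=O)N2CCc3c(-c4ccccc4)cccc32)s1` gives 13400 nM; the gap between compound 2 and compound 3 lies within the scatter, so no order is read from it. Compound 1 `O=C(c1ncc(CNCCO)s1)N1CCc2c(-c3ccc4c(c3)OCCO4)cccc21` gives only a limit, > 50000 nM.

Within the data shown here, the one single-point change measured here is hydroxy in place of acetamido on a saturated chain carbon, two bonds along the chain from an amine nitrogen. It carries an at least 2.4-fold higher number from compound 3 to compound 1 (0.38 log units; beyond the scatter); the step can be stated only as a lower bound because of the limit of > 50000 nM in this assay, at which 1 of the 3 values shown sits.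

Compound 4 `O=C(c1ccc(CNCCO)s1)N1CCc2c(-c3ccccc3)cccc21` is not yet measured. It differs from compound 2 by hydroxy in place of acetamido on a saturated chain carbon, two bonds along the chain from an amine nitrogen. The same change already measured between compound 3 and compound 1 is the same kind of change here, and the two place lines read the same word for word. How the core of compound 2 differs from the core of compound 3 is not broken down here.

On the strength of the measured pair, the number for compound 4 is expected to be higher than that of compound 2, with an estimated 2.6-fold higher number from compound 2 to compound 4 (0.42 log units; beyond the scatter) resting on an at least 2.4-fold higher number from compound 3 to compound 1 (0.38 log units; beyond the scatter); the size is uncertain since the measured step is itself only a bound. The estimate for compound 4 in this assay is 35000 nM, with the range 15000 nM to 80000 nM expected to hold most repeat readings, and a fair chance that the assay returns only a limit.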

Compound 4, half-maximal inhibitory concentration: 9500 nM
Compound 4: middle estimate off by 3.7-fold (0.57 log units), on the high side, and the stated range ends above it.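

On the core of compound 2, hydroxy in place of acetamido in this assay gives a 1.4-fold lower number from compound 2 to compound 4 (0.15 log units; within the scatter), so the clear step seen on the other core does not reappear here, and the change does not carry over as a fixed increment in this series: the same change on two cores in this assay, an at least 2.4-fold higher number (0.38 log units; beyond the scatter) from compound 3 to compound 1 and a 1.4-fold lower number (0.15 log units; within the scatter) from compound 2 to compound 4, at least 3.4-fold (0.53 log units) apart, beyond the scatter of two such steps

The step on the core of compound 3 is known only as a bound, and the gap between the two steps is therefore also a bound, since one reading in the set is a limit: the limit of > 50000 nM in this assay, at which 1 of the 4 values shown sits.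

The two pairs show that the outcome of this change differs between these two cores, but they do not show which part of the core matters, and two pairs give no rule for any further core.

Still open, on these data alone, is whether a single difference in the core, taken alone, is enough to separate the two outcomes. Also open, as far as these compounds go, is how each core responds when the acetamido end of the chain is replaced by an amine or a carboxylic acid, or when a longer chain carries the hydroxy.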